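The source may report more compounds than this note shows. Statements on the series, on what has been measured and on what is new or still open speak of the compounds shown alone.

Of the compounds shown here, three built on a shared core have so far been measured in an ADME assay for permeability, using PAMPA, with a stated time of 18 h (a higher number here means that the compound crosses the layer faster, a lower number that the compound crosses the layer more slowly), and all give similar numbers. Compound 1 (`CCS(=O)(=O)N1CCC(c2cncc(N3C(=O)c4ccc(Cl)cc4C3(C)C)c2)CC1`) gives 4.01 10^-6 cm/s in this test. Compound 2 (`CC1(C)c2cc(Cl)ccc2C(=O)N1c1cncc(OC2CN(C(=O)c3ncccc3Cl)C2)c1`) gives 3.32 10^-6 cm/s in this test. Compound 3 (`Cn1cc(C(=O)N2CC3(C2)CN(c2cncc(N4C(=O)c5ccc(Cl)cc5C4(C)C)c2)C3)cn1`) gives 3.63 10^-6 cm/s in this test. Compound 2 therefore stands level with the other two, as all three numbers lie within the scatter of repeated measurements.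

Compound 4 (`Cn1cc(C(=O)N2CC(Oc3cncc(N4C(=O)c5ccc(Cl)cc5C4(C)C)c3)C2)cn1`) has not yet been measured. It differs from compound 2 in one place: on a carbonyl carbon, 1-methyl-1H-pyrazol-4-yl stands in place of 3-chloropyridin-2-yl (1-methyl-1H-pyrazol-4-yl in place of 3-chloropyridin-2-yl on a carbonyl carbon). For the measured compounds named here, no measured pair isolates this change. Compound 3 also carries 1-methyl-1H-pyrazol-4-yl on a carbonyl carbon, though it differs elsewhere, and its 3.63 10^-6 cm/s lies within the scatter of compound 2. The expected step, a 1.1-fold higher number from compound 2 to compound 4 (0.02 log units; within the scatter), is estimated to stay within the scatter, with no clear direction. The estimated value for compound 4 is 3.5 10^-6 cm/s, with an expected range from 1.8 10^-6 cm/s to 7 10^-6 cm/s in this test.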

Compound 4, apparent permeability: 3.45 10^-6 cm/s
Compound 4: middle estimate off by 1.0-fold (0.01 log units), on the high side; measured number inside the range.
By their numbers in this assay, from the lowest: compounds 2, 4, 3 and 1 (each within the scatter of the next).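

For the compounds shown here, compound 2 and compound 4 form the first measured pair that differs in only one place, so this change can now be read directly instead of being inferred from compounds that also differ elsewhere. In this assay, 1-methyl-1H-pyrazol-4-yl in place of 3-chloropyridin-2-yl on a carbonyl carbon gives a 1.0-fold higher number from compound 2 to compound 4 (0.02 log units; within the scatter), so swapping these two aromatic rings at this position produces no step beyond the scatter. Nothing in the data offers an explanation for this result.

Going by these compounds alone, this pair covers only two aromatic groups with no net charge, on one version of the shared core, so whether the same swap reads alike on other versions remains open. On these data alone, it is also open what an amine, a carboxylic acid or a longer chain on this carbonyl carbon would do to the number.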